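Norbornyl-type amide in place of cycloheptyl on an adenosine carboxamide

A few compounds are considered here, and "the series" means these few. Any claim that something is new, unique, unknown or untested is made for them only; others in the source may bear on it.

Measured compounds:
compound 1 `NC(=O)[C@H]1OC(n2cnc3c(N)ncnc32)[C@H](O)[C@@H]1O`, 64 nM
compound 2 `CCCCCCCCNC(=O)[C@H]1OC(n2cnc3c(N)ncnc32)[C@H](O)[C@@H]1O`, 21 nM
compound 3 `Nc1ncnc2c1ncn2C1O[C@H](C(=O)NC2CCCCCC2)[C@@H](O)[C@H]1O`, 22 nM

In an assay on cell membranes for binding affinity to 2-oxoglutarate receptor 1 (Rattus norvegicus), read by radioligand binding (on this read-out higher numbers stand for weaker inhibition and lower numbers for stronger inhibition), compound 1 gives 64 nM. Adding a chain to the amide nitrogen helps: a 3.0-fold lower number from compound 1 to compound 2 (0.48 log units; beyond the scatter), and a ring does the same: a 2.9-fold lower number from compound 1 to compound 3 (0.46 log units; beyond the scatter). Between the two substituted amides the shape of the group hardly matters, since a 1.0-fold higher number from compound 2 to compound 3 (0.02 log units; within the scatter). Compound 3 thus stands second of the three, indistinguishable from compound 2 and clearly stronger than compound 1.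

Compound 4 `Nc1ncnc2c1ncn2C1O[C@H](C(=O)NC2CC3CCC2C3)[C@@H](O)[C@H]1O` carries a group of 7 heavy atoms (7 carbon; 2 five-membered non-aromatic rings of carbon only) in place of a group of 7 heavy atoms (7 carbon; one seven-membered non-aromatic ring of carbon only), on an amide-type nitrogen. Within the data shown here, the only step that bears on it is the one from compound 2 to compound 3, which was within the scatter, so an exchange of one seven-carbon group for another is expected to leave the number about where it is, with no step beyond the scatter: no change at the digits printed from compound 3 to compound 4 (within the scatter). Compound 4 is therefore estimated at 22 nM, with a range of 10 nM to 50 nM.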

Compound 4, inhibition constant: 640 nM
Estimate against measurement, compound 4: 29-fold (1.46 log units) below; the measured number lies above the stated range.
By their numbers in this assay, from the lowest: compounds 2 and 3 (each within the scatter of the next); then compound 1; then compound 4.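

In this assay the amide-type nitrogen proves far from indifferent to the shape of its group: with the carbon count unchanged, the group with 2 five-membered rings gives a 29-fold higher number from compound 3 to compound 4 (1.46 log units; beyond the scatter) in place of cycloheptyl, so the earlier agreement between chain and ring does not extend to every seven-carbon group. The open octyl chain also separates clearly from this group, with a 30-fold higher number from compound 2 to compound 4 (1.48 log units; beyond the scatter) in the step to it, and substitution on this nitrogen, which helped in compound 2 and compound 3, here does the reverse, with a 10-fold higher number from compound 1 to compound 4 (1.00 log units; beyond the scatter) measured against the plain amide. Nothing available explains this reversal.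

The compounds shown leave open how the number moves between these groups. Cyclohexyl or cyclopentyl on the same nitrogen could show whether the change follows ring size or the two-ring arrangement itself.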